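Methylating a catechol hydroxy on an inactive nitrocatechol amide

The source may hold more compounds than are shown below. What is called first, only, known or untested is meant among the compounds shown, and "the series" means these compounds.

Measured compounds:
Compound 1 `Cc1cccc(NC(=O)/C(C#N)=C/c2cc(O)c(O)c([N+](=O)[O-])c2)c1` gives 5.6 ug/mL in a functional assay on BGC-823 cells (Homo sapiens) for antiproliferative activity, read by MTT assay; on this read-out lower numbers stand for stronger inhibition and higher numbers for weaker inhibition.
Compound 2 `COc1ccc(NC(=O)/C(C#N)=C/c2cc(O)c(O)c([N+](=O)[O-])c2)cc1` gives 45.4 ug/mL.
Compound 3 `N#C/C(=C\c1cc(O)c(O)c([N+](=O)[O-])c1)C(=O)Nc1cccc(Cl)c1` shows only a limit, > 100 ug/mL.

Compound 3 stands at the bottom of this small set: it sits at the limit of > 100 ug/mL in this assay, at which 1 of the 3 values shown sits, so its inhibition is too weak to be measured as a number. The three measured steps all change the group on the amide-type nitrogen: an 8.1-fold higher number from compound 1 to compound 2 (0.91 log units; beyond the scatter), an at least 17-fold higher number from compound 1 to compound 3 (1.25 log units; beyond the scatter) and an at least 2.2-fold higher number from compound 2 to compound 3 (0.34 log units; beyond the scatter).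

Compound 4 `COc1cc(/C=C(\C#N)C(=O)Nc2cccc(Cl)c2)cc([N+](=O)[O-])c1O` differs from compound 3 only by methyl in place of hydrogen on an oxygen on an aromatic ring. Among the compounds with values here, none of the measured steps touches this oxygen, so no measured step bears directly on the change; the data give no size for it. Since compound 3 already lies at the limit, compound 4 is expected to remain at or beyond it, with an estimated step that the limit leaves unreadable from compound 3 to compound 4. Compound 4 is therefore estimated at 150 ug/mL, within a range of 40 ug/mL to 600 ug/mL.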

Compound 4, half-maximal inhibitory concentration: 26.1 ug/mL
Compound 4: the middle estimate sits 5.7-fold (0.76 log units) above what was measured, outside the stated range (below it).
By their numbers in this assay, from the lowest: compound 1; then compounds 4 and 2 (each within the scatter of the next). At a limit, above all of these: compound 3.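

Turning hydroxy to methoxy on this aromatic ring gives an at least 3.8-fold lower number from compound 3 to compound 4 (0.58 log units; beyond the scatter) in this assay, so a change at this oxygen can move the read-out, and with the 3-chlorophenyl group on the amide nitrogen a free hydroxy here is not needed for a measurable value. This is the first step shown that leaves the group on the amide nitrogen untouched and changes the shared core instead. The true size of the step cannot be read, because compound 3 sits at a limit: the limit of > 100 ug/mL in this assay, at which 1 of the 4 values shown sits.

Whether the same change would help with the 3-methylphenyl group of compound 1 or the 4-methoxyphenyl group of compound 2 stays open, as the compounds shown hold it in one pair only. Also open, from the compounds shown here alone, is how ethyl or a longer chain on this oxygen would read.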